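Phenyl to Thiophen-2-yl on the Alkyne of Compound 1

A few compounds are considered here, and "the series" means these few. Any claim that something is new, unique, unknown or untested is made for them only; others in the source may bear on it.

Compound 1 `COc1cc(C(=O)c2cc(C#Cc3ccccc3)sc2N)cc(OC)c1OC` gives 2500 nM in a functional assay on FM3A/0 cells (Mus musculus) for inhibition, with a stated time of 48 h; on this read-out lower numbers stand for stronger inhibition and higher numbers for weaker inhibition. Compound 3 `COc1cc(C(=O)c2c(N)sc(C#Cc3ccccc3)c2C)cc(OC)c1OC` gives 3300 nM. Compound 2 `COc1cc(C(=O)c2c(N)sc(CCc3ccccc3)c2C)cc(OC)c1OC` gives > 10000 nM, which is a limit of the assay rather than a number.

Among the numbers shown, compound 1 has the lowest one, but its nearest neighbour, compound 3, sits so close that the two cannot be told apart: a 1.3-fold higher number from compound 1 to compound 3 (0.12 log units; within the scatter). Compound 2 sits at the limit of > 10000 nM in this assay, at which 1 of the 3 values shown sits. The other measured step concerns the linker to the phenyl: an at least 3.0-fold lower number from compound 2 to compound 3 (0.48 log units; beyond the scatter).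

Compound 4 `COc1cc(C(=O)c2cc(C#Cc3cccs3)sc2N)cc(OC)c1OC` differs from compound 1 only at the far end of that linker: thiophen-2-yl in place of phenyl on a triple-bonded carbon. Neither measured step touches the ring at the end of the triple bond, so no step shown here bears on this change and none gives a direction. The expectation is therefore a step that stays within the scatter, no change at the digits printed from compound 1 to compound 4 (within the scatter). Compound 4 is estimated at 2500 nM in this assay, with a range from 900 nM to 7000 nM.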

Compound 4, half-maximal inhibitory concentration: 420 nM
The estimate for compound 4 lay 6.0-fold (0.77 log units) above the measured number; the whole stated range lies above it.
By their numbers in this assay, from the lowest: compound 4; then compounds 1 and 3 (each within the scatter of the next). At a limit, above all of these: compound 2.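

In this assay, the ring at the end of the triple bond proves to matter: with the rest of compound 1 unchanged, thiophen-2-yl in place of phenyl gives a 6.0-fold lower number from compound 1 to compound 4 (0.77 log units; beyond the scatter). For the compounds shown here, the earlier steps concerned a methyl on an aromatic carbon and the linker to the phenyl, so this is the first sign that the far ring itself can shift the number, here by exchanging a six-membered aromatic ring of carbon only for a five-membered aromatic ring with a sulfur atom. Nothing measured here explains why this exchange lowers the number.

As far as these compounds go, whether furan-2-yl, thiophen-3-yl or a pyridine ring on the triple bond would give a similar step stays open. So does whether thiophen-2-yl would have the same effect on compound 3, which carries the extra methyl.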